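This account rests on a few compounds, and the source may have more. Where it says the series, first, only, none or still open, it means among the compounds named here.

In a functional assay on BMMC cells (Mus musculus, strain BALB/c) for antiproliferative activity, read by MTT assay, with a stated time of 48 h (a lower number here means a stronger inhibitor, a higher number a weaker inhibitor), compound 1 `COc1cc(Nc2nc(N3CCC(NC(=O)c4ccc(C(=O)O)cn4)C3)nc3c2COC3)cc(OC)c1OC` gives 21100 nM, while compound 2 `COc1cc(Nc2nc(N3CCC(NC(=O)c4ccc(C(=O)O)cn4)C3)nc3c2COC3)cc(OC)c1` gives 2000 nM, the lower of these two numbers. Compound 3 `CCCCCCCNc1nc(N2CCC(NC(=O)c3ccc(C(=O)O)cn3)C2)nc2c1COC2` differs from compound 2 as follows: heptyl in place of 3,5-dimethoxyphenyl on a nitrogen on an aromatic ring. Among the measured compounds shown here, only one measured step bears on this group: an 11-fold lower number from compound 1 to compound 2 (1.02 log units; beyond the scatter), with hydrogen in place of methoxy on an aromatic carbon. That step was large, so replacing the whole group may also move the number beyond the scatter, though the direction remains uncertain. The expected change, a moderate rise, is a 2.5-fold higher number from compound 2 to compound 3 (0.40 log units; beyond the scatter). For compound 3, the estimated value is 5000 nM, with an expected range of 1000 nM to 25000 nM.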

Compound 3, half-maximal inhibitory concentration: 13000 nM
Compound 3: the middle estimate sits 2.6-fold (0.41 log units) below what was measured, and the stated range covers the measured number.
By their numbers in this assay, from the lowest: compound 2; then compounds 3 and 1 (each within the scatter of the next).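

Heptyl on this nitrogen gives a 6.5-fold higher number from compound 2 to compound 3 (0.81 log units; beyond the scatter) in this assay and so does not stand in for 3,5-dimethoxyphenyl. Set against 3,4,5-trimethoxyphenyl, the same chain gives a 1.6-fold lower number from compound 1 to compound 3 (0.21 log units; within the scatter) and that step lies within the scatter, so a compound without a ring at this place can match the 3,4,5-trimethoxyphenyl compound. The lowest number of the three still belongs to compound 2.

As far as these compounds go, whether a shorter chain such as butyl, or a plain phenyl or cyclohexyl ring, would come closer to compound 2 stays open. Why the chain and the two rings compare this way also stays open, and nothing measured here addresses it.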